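The source may report more compounds than this note shows. Statements on the series, on what has been measured and on what is new or still open speak of the compounds shown alone.

Compound 2 `CCOc1ccc(NC(=S)N2CCC(C(O)(c3ccccc3)c3ccccc3)CC2)cc1C#N` gives 323 nM in a functional assay for antagonist activity at Neuropeptide Y receptor type 2 (Homo sapiens); on this read-out lower numbers stand for stronger inhibition and higher numbers for weaker inhibition. Among the compounds with values here, it stands at one end of the two numbers measured so far, yet its gap to compound 1 `CN(C)c1ccc(NC(=S)N2CCC(C(O)(c3ccccc3)c3ccccc3)CC2)cc1`, which gives 612 nM, is within the scatter, so the two cannot be told apart. Within the data shown here, the one measured step, a 1.9-fold lower number from compound 1 to compound 2 (0.28 log units; within the scatter), changes the same position. Compound 3 `CCOc1ccc(NC(=S)N2CCC(C(O)(c3ccccc3)c3ccccc3)CC2)c(F)c1` differs from compound 2 by 4-ethoxy-2-fluorophenyl in place of 3-cyano-4-ethoxyphenyl on an amide-type nitrogen. With that step inside the scatter, compound 3 is expected to move by a 1.3-fold higher number from compound 2 to compound 3 (0.11 log units; within the scatter), that is, not beyond the scatter. Compound 3 is estimated at 420 nM, ranging from 150 nM to 1200 nM.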

Compound 3, half-maximal inhibitory concentration: 1350 nM
Compound 3: the middle estimate sits 3.2-fold (0.51 log units) below what was measured, outside the stated range (above it).
By their numbers in this assay, from the lowest: compounds 2 and 1 (each within the scatter of the next); then compound 3.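

Replacing 3-cyano-4-ethoxyphenyl with 4-ethoxy-2-fluorophenyl gives a 4.2-fold higher number from compound 2 to compound 3 (0.62 log units; beyond the scatter) and shows that this position on the amide-type nitrogen does respond to the group it carries. Replacing 4-(dimethylamino)phenyl with the same group gives a 2.2-fold higher number from compound 1 to compound 3 (0.34 log units; beyond the scatter) and makes compound 3 the weakest inhibitor of the three. Nothing available explains these rises. The compounds shown leave open how a carboxylic acid or a longer chain in place of the ethoxy group would read. They also leave open whether an unsubstituted phenyl would match compound 3 or compound 2.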